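From cyclopropyl to dimethylamino on a sulfonyl sulfur

A few compounds are considered here, and "the series" means these few. Any claim that something is new, unique, unknown or untested is made for them only; others in the source may bear on it.

compound 1 `CC(C)(C)OC(=O)N[C@H]1CCCCC/C=C\[C@@H]2C[C@@]2(C(=O)NS(=O)(=O)C2CC2)NC(=O)[C@@H]2C[C@@H](OC(=O)N3CCc4ccccc4C3)CN2C1=O`: 60 ng.h/mL
compound 2 `CC(C)(C)OC(=O)N[C@H]1CCCCC/C=C\[C@@H]2C[C@@]2(C(=O)NS(=O)(=O)C2CC2)NC(=O)[C@@H]2C[C@@H](OC(=O)N3Cc4ccccc4C3)CN2C1=O`: 32900 ng.h/mL

Both compounds were read in an ADME assay on the whole organism (plasma, Rattus norvegicus, strain Sprague-Dawley) for pharmacokinetics, read by LC-MS, with a stated time of 24 h, at a dose of 30 mg/kg by the oral route (on this read-out lower numbers stand for lower exposure and higher numbers for higher exposure at the dose given), and compound 2, at 32900 ng.h/mL, holds the higher of the two numbers. Compound 3 `CN(C)S(=O)(=O)NC(=O)[C@@]12C[C@H]1/C=C\CCCCC[C@H](NC(=O)OC(C)(C)C)C(=O)N1C[C@H](OC(=O)N3Cc4ccccc4C3)C[C@H]1C(=O)N2` has not yet been measured. It differs from compound 2 in one place: dimethylamino in place of cyclopropyl on a sulfonyl sulfur. In plain words, dimethylamino stands in place of cyclopropyl on a sulfonyl sulfur.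

Within the data shown here, only one measured step is available, a 550-fold higher number from compound 1 to compound 2 (2.74 log units; beyond the scatter). That step was large, but it concerns a different group, on a carbonyl carbon, and so says nothing direct about the change at the sulfonyl sulfur. It shows only that, in this pair, one exchange moved the read-out far, so a wide range is warranted. Among the measured compounds shown here, no measurement yet tests the new change. With compound 2 already at 32900 ng.h/mL, a moderate fall seems more likely than a further rise. The expected step is a 2.7-fold lower number from compound 2 to compound 3 (0.44 log units; beyond the scatter), an estimate held with little certainty. For compound 3 the estimated value in this assay is 12000 ng.h/mL, with an expected range of 1500 ng.h/mL to 60000 ng.h/mL.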

Compound 3, area under the concentration-time curve in the plasma assay: 1030 ng.h/mL
The estimate for compound 3 lay 12-fold (1.07 log units) above the measured number; measured number below the stated range.
By their numbers in the plasma assay, from the lowest: compound 1; then compound 3; then compound 2.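

In the plasma assay, compound 2 gives 32900 ng.h/mL and compound 3 gives 1030 ng.h/mL; dimethylamino in place of cyclopropyl on a sulfonyl sulfur gave a 32-fold lower number from compound 2 to compound 3 (1.50 log units; beyond the scatter), so this second site on the shared core can also shift exposure strongly, which the earlier pair, changed only on a carbonyl carbon, could not show. The exchange keeps the heavy-atom count and the counted hydrogen-bond donors and acceptors the same, yet it removes the three-membered ring and brings in a nitrogen, and these counts alone therefore do not account for the large step. In a physicochemical assay for lipophilicity (a higher number here means a more lipophilic compound, a lower number a more polar compound), compound 2 gives 2.4 and compound 3 gives 2.5; the same exchange gave a number 0.10 log units higher from compound 2 to compound 3 (within the scatter), which lies within the scatter, and the data shown offer no explanation for the step in exposure.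

The compounds shown cannot separate the loss of the ring from the entry of the nitrogen: an open-chain isopropyl group or a pyrrolidinyl ring on the same sulfonyl sulfur would bear on that question. It also remains open whether the step would be of similar size with a different group on the carbonyl carbon, as only one such context is shown here.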